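Series notes: from compound 3 to compound 4

A few compounds are considered here, and "the series" means these few. Any claim that something is new, unique, unknown or untested is made for them only; others in the source may bear on it.

Measured so far in an ADME assay on NIH3T3 cells (Mus musculus) for inhibition, read by sulforhodamine B assay, with a stated time of 48 h; on this read-out lower numbers stand for stronger inhibition of growth and higher numbers for weaker inhibition of growth:
- compound 1 `COc1cc(C(=O)NNC(=O)c2ccc3[nH]c(-c4ccc([N+](=O)[O-])s4)nc3c2)cc(OC)c1OC` gives 31.3 ug/mL
- compound 2 `COc1cccc(C(=O)NNC(=O)c2ccc3[nH]c(-c4ccc([N+](=O)[O-])o4)nc3c2)c1` gives 15.6 ug/mL
- compound 3 `O=C(NNC(=O)c1cc2ccccc2cc1O)c1ccc2[nH]c(-c3ccc([N+](=O)[O-])s3)nc2c1` gives 31.3 ug/mL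

Compound 3 stands at 31.3 ug/mL and reads level with compound 1 at 31.3 ug/mL at the digits given, while compound 2 at 15.6 ug/mL lies within the scatter of both. Compound 4 `COc1cccc(C(=O)NNC(=O)c2ccc3[nH]c(-c4ccc([N+](=O)[O-])s4)nc3c2)c1` has 3-methoxyphenyl in place of 3-hydroxynaphthalen-2-yl on a carbonyl carbon and has not yet been measured. Within the data shown here, the measured compounds offer no step that differs in one place, so this change has no direct guide. Compound 2 also carries 3-methoxyphenyl, and its 15.6 ug/mL sits within the scatter of compound 3 at 31.3 ug/mL in this assay so no move beyond the scatter is expected, in either direction. The estimate means a 1.3-fold lower number from compound 3 to compound 4 (0.10 log units; within the scatter) and this expected step stays within the scatter. For compound 4 the estimated value is 25 ug/mL and the expected range runs from 10 ug/mL to 62 ug/mL until the measurement arrives.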

Compound 4, concentration for 50% growth inhibition: 15.6 ug/mL
Beside the measured number, compound 4's estimate is 1.6-fold (0.20 log units) above it, within the range that was stated.
By their numbers in this assay, from the lowest: compounds 2, 4, 1 and 3 (each within the scatter of the next).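

In this assay, among these compounds, compound 4 supplies the single-place comparisons that the earlier compounds lacked. On the carbonyl carbon, 3-methoxyphenyl in place of 3-hydroxynaphthalen-2-yl gives a 2.0-fold lower number from compound 3 to compound 4 (0.30 log units; within the scatter) and, on the aromatic carbon, 5-nitrothiophen-2-yl in place of 5-nitrofuran-2-yl gives no change at the digits printed from compound 2 to compound 4 (within the scatter), so neither change moves the read-out beyond the scatter for these pairs. No measured evidence at hand bears on these two results.

Still open, from the compounds shown here alone, is whether a different kind of group on the carbonyl carbon, such as an aminophenyl, a carboxyphenyl or a longer alkyl chain, would give a step beyond the scatter. Equally open, going by these compounds, is what a nitrile in place of the nitro group on the thiophene or furan ring would do to the read-out.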